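The source may report more compounds than this note shows. Statements on the series, on what has been measured and on what is new or still open speak of the compounds shown alone.

Measured compounds:
- compound 1 `CN1C(=O)N(c2ccccc2)C2NC(=S)N(/N=C/C=C/c3ccccc3)C21`; in a functional assay on MCF7 cells (Homo sapiens) for inhibition, read by MTT assay, with a stated time of 72 h (a lower number here means a stronger inhibitor, a higher number a weaker inhibitor), compound 1 reaches only a limit, > 100000 nM
- compound 2 `CCN1C(=O)N(c2ccccc2)C2NC(=S)N(/N=C/C=C/c3ccccc3)C21`; in this assay compound 2 gives 2250 nM
- compound 3 `CCN1C(=O)N(CC)C2C1N=C(SC)N2/N=C/C=C/c1ccccc1[N+](=O)[O-]`; in this assay compound 3 gives 66700 nM

Compound 1 and compound 2 differ by methyl in place of hydrogen on a saturated chain carbon bound to an amide-type nitrogen in a ring, and in this assay this gives an at least 44-fold lower number from compound 1 to compound 2 (1.64 log units; beyond the scatter); the step is known only as a lower bound because of the limit of > 100000 nM in this assay, at which 1 of the 3 values shown sits.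

Compound 4 `CCSC1=NC2C(N(CC)C(=O)N2CC)N1/N=C/C=C/c1ccccc1[N+](=O)[O-]` differs from compound 3 by methyl in place of hydrogen on a saturated chain carbon bound to a sulfur. The difference between the core of compound 3 and the core of compound 1 is not broken down here. The change from compound 3 to compound 4 is the same kind of change as that from compound 1 to compound 2, but not the same: in the earlier pair it sits on a saturated chain carbon bound to an amide-type nitrogen in a ring, here on a saturated chain carbon bound to a sulfur. Starting from compound 3 at 66700 nM, a gain is expected, but a smaller one than an at least 44-fold lower number from compound 1 to compound 2 (1.64 log units; beyond the scatter), since the place differs. The estimated step is a 3.0-fold lower number from compound 3 to compound 4 (0.48 log units; beyond the scatter). Compound 4 is estimated at 22000 nM, between 5000 nM and 90000 nM.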

Compound 4, half-maximal inhibitory concentration: 30700 nM
For compound 4 the middle estimate is 1.4-fold (0.14 log units) below the measured one, and the stated range covers the measured number.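

In this assay, methyl in place of hydrogen on a saturated chain carbon bound to a sulfur, which turns methylsulfanyl into ethylsulfanyl, gives a 2.2-fold lower number from compound 3 to compound 4 (0.34 log units; beyond the scatter). Set beside the earlier step, the direction carries over from one core to the other, while the size does not: the same change on two cores in this assay, an at least 44-fold lower number (1.64 log units; beyond the scatter) from compound 1 to compound 2 and a 2.2-fold lower number (0.34 log units; beyond the scatter) from compound 3 to compound 4, at least 20-fold (1.31 log units) apart, beyond the scatter of two such steps

Compound 1 gives > 100000 nM, which is a limit and not a number, so the earlier step is known only as a bound, and these two pairs do not show whether the core or the place of the methyl sets the gap between the steps.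

The compounds shown leave open whether a longer chain, such as propyl in place of the ethyl on the sulfur, would lower the number further, and what an amine in place of the ethylsulfanyl group would give. Going by these compounds alone, they also offer no pair with the same change at the same place on both cores, which would separate the effect of the core from that of the place.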